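A few compounds are considered here, and "the series" means these few. Any claim that something is new, unique, unknown or untested is made for them only; others in the source may bear on it.

Measured in a functional assay on HeLa cells (Homo sapiens) for inhibition, with a stated time of 72 h; on this read-out lower numbers stand for stronger inhibition and higher numbers for weaker inhibition:
- compound 1 `NC1CCC(Nc2nc(NCc3ccc(Br)cc3)c3ncn(C4CCCC4)c3n2)CC1`: 1510 nM
- compound 2 `NC1CCC(Nc2nc(NCc3ccc(-c4ccco4)nc3)c3ncn(C4CCCC4)c3n2)CC1`: 30 nM
- compound 3 `OC1CCC(Nc2nc(NCc3ccc(-c4ccco4)nc3)c3ncn(C4CCCC4)c3n2)CC1`: 247 nM

Compound 1 has the highest number of the three, so it is the weakest inhibitor here. Compound 4 `NC1CCC(Nc2nc(NCc3ccc(-c4ccccc4O)cc3)c3ncn(C4CCCC4)c3n2)CC1` has not yet been measured. It keeps the rest of compound 1 but carries 2-hydroxyphenyl in place of bromo on an aromatic carbon.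

The closest guide is a 50-fold lower number from compound 1 to compound 2 (1.70 log units; beyond the scatter), a large drop that came with 6-(furan-2-yl)pyridin-3-yl in place of 4-bromophenyl. That change also extends the group at this end of the molecule, but with different rings, so it is only a partial precedent. The other measured change, an 8.2-fold higher number from compound 2 to compound 3 (0.92 log units; beyond the scatter), swaps amino for hydroxy on a saturated ring carbon. Compound 4 keeps that amino group, so this step offers no direct guide.

The expected change is a 10-fold lower number from compound 1 to compound 4 (1.00 log units; beyond the scatter), towards a lower number but probably smaller than the drop seen with the furan-bearing group. For compound 4 the estimated value is 150 nM, with an expected range of 40 nM to 600 nM.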

Compound 4, half-maximal inhibitory concentration: 4180 nM
Estimate against measurement, compound 4: 28-fold (1.45 log units) below; the measured number lies above the stated range.
By their numbers in this assay, from the lowest: compound 2; then compound 3; then compound 1; then compound 4.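

In this assay the step of a 2.8-fold higher number from compound 1 to compound 4 (0.44 log units; beyond the scatter) came with 2-hydroxyphenyl in place of bromo on this aromatic carbon. A larger group with a second aromatic ring at this end therefore does not by itself bring a lower number. The step of a 50-fold lower number from compound 1 to compound 2 (1.70 log units; beyond the scatter) goes the other way, so the two changes made from compound 1 point in opposite directions and the identity of the added rings matters here.

Still open, as far as these compounds go, is how a plain phenyl or a 2-methoxyphenyl would compare at this aromatic carbon, which would separate the added ring from its hydroxy group. Also open, from the compounds shown here alone, is whether furan-2-yl in place of bromo, with the benzene ring of compound 1 kept, would give a lower number.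

Nothing available explains why this change raised the number.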